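Carbamoyl for trifluoromethyl in a series tolerated by cells

The source may hold more compounds than are shown below. What is called first, only, known or untested is meant among the compounds shown, and "the series" means these compounds.

Compound 1 `CCOC(=O)c1cnc(N2CCN(Cc3ccc(C(F)(F)F)cc3)CC2)nc1Oc1c(C)cc(-c2ccc(C#N)cc2)cc1C` is the starting point. In an ADME assay on MT4 cells (Homo sapiens) for cytotoxicity, read by MTT assay, with a stated time of 4 days (a lower number here means that less compound is tolerated, a higher number that more compound is tolerated), compound 1 reaches only the limit of the assay, > 125000 nM, not a measured number. Compound 2 `CCOC(=O)c1cnc(N2CCN(Cc3cccc(F)c3)CC2)nc1Oc1c(C)cc(-c2ccc(C#N)cc2)cc1C` likewise stops at the limit in this assay, giving > 125000 nM. Compound 3 `CCOC(=O)c1cnc(N2CCN(Cc3cccc(C(=O)OC)c3)CC2)nc1Oc1c(C)cc(-c2ccc(C#N)cc2)cc1C` also gives a limit in this assay, namely > 125000 nM. The steps a step that the two limits leave unreadable from compound 1 to compound 2, a step that the two limits leave unreadable from compound 1 to compound 3 and a step that the two limits leave unreadable from compound 2 to compound 3 are therefore without readable size, because all three values sit at the limit of > 125000 nM in this assay, at which 3 of the 3 values shown sit.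

Compound 4 `CCOC(=O)c1cnc(N2CCN(Cc3ccc(C(N)=O)cc3)CC2)nc1Oc1c(C)cc(-c2ccc(C#N)cc2)cc1C` differs from compound 1 in one place: carbamoyl in place of trifluoromethyl on an aromatic carbon. Within the data shown here, no measured step matches this change, and the measured steps that exist give no readable size at all. Among the measured compounds shown here, the only guidance is that every compound measured so far sits at the limit. Compound 4 is therefore expected to show a step that the limit leaves unreadable from compound 1 to compound 4, that is, no readable change, and most likely another limit. Compound 4 is estimated at 200000 nM in this assay, with a range from 125000 nM to 500000 nM.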

Compound 4, half-maximal cytotoxic concentration: 66500 nM
Compound 4: the middle estimate sits 3.0-fold (0.48 log units) above what was measured; the whole stated range lies above it.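

In this assay, compound 4 is the only one of the four compounds that gives a measured number rather than a limit, so carbamoyl on this aromatic carbon brings the series into the readable range: the limit of > 125000 nM in this assay, at which 3 of the 4 values shown sit.

Replacing trifluoromethyl with carbamoyl gives an at least 1.8-fold lower number from compound 1 to compound 4 (0.27 log units; that floor lies within the scatter), and the changes of the whole substituted phenyl give an at least 1.8-fold lower number from compound 3 to compound 4 (0.27 log units; that floor lies within the scatter) and an at least 1.8-fold lower number from compound 2 to compound 4 (0.27 log units; that floor lies within the scatter). As far as these compounds go, each of these steps is only a floor that lies within the scatter, so the result marks a possible drop in tolerance, and its true size stays unknown.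

The compounds shown leave open whether a carboxylic acid, an amine or an N-methyl amide on the same aromatic carbon would also give a measured number. They also do not tell how far the true value of compound 1 lies beyond its limit.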